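The compounds below may be only part of what the source reports. "The series", "measured", "known", "first", "only" and "open" are said of these compounds alone.

Measured compounds:
compound 1, `O=C1CCC(=O)N1Cc1cc2nccc(-c3cc(Cl)cc4c3O[C@@H](c3onc5c3CNCC5)C4)c2s1`, 0.38 nM
compound 2, `O=C([C@H]1Cc2cc(Cl)cc(-c3ccnc4cc(C5(O)COC5)sc34)c2O1)N1CCNCC1`, 73 nM
compound 3, `Cc1cc(Cl)cc(-c2ccnc3cc(CN4C(=O)C5CC5C4=O)sc23)c1C[C@H]1OCCN[C@@H]1C`, 1.5 nM

In an assay on isolated protein for inhibition of ubiquitin carboxyl-terminal hydrolase 7 (Homo sapiens), read by fluorescence, with stated times of 30 min and 1 h (a lower number here means a stronger inhibitor, a higher number a weaker inhibitor), compound 2 gives 73 nM, the highest of the three numbers: compound 3 shows 1.5 nM and compound 1 shows 0.38 nM, both gaps lying beyond the scatter, so compound 2 is the weakest inhibitor of the three. Compound 4, `O=C([C@H]1Cc2cc(Cl)cc(-c3ccnc4cc(C(O)(CO)CCl)sc34)c2O1)N1CCNCC1`, differs from compound 2 by 1-(chloromethyl)-1,2-dihydroxyethyl in place of 3-hydroxyoxetan-3-yl on an aromatic carbon. Among the measured compounds shown here, no pair of measured compounds here differs in that one place, so nothing measured anchors the step. The two groups keep the same number of acceptors and gain one donor while the ring is lost; a small step is expected, most likely toward a weaker inhibitor or none beyond the scatter. The step from compound 2 to compound 4 is estimated as a 1.5-fold higher number from compound 2 to compound 4 (0.18 log units; within the scatter). Compound 4 is expected to give about 110 nM, within 35 nM to 350 nM.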

Compound 4, half-maximal inhibitory concentration: 9 nM
Compound 4: middle estimate off by 12-fold (1.09 log units), on the high side; the whole stated range lies above it.
By their numbers in this assay, from the lowest: compound 1; then compound 3; then compound 4; then compound 2.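

In this assay, the aromatic carbon next to the ring sulfur proves sensitive to its substituent: 1-(chloromethyl)-1,2-dihydroxyethyl in place of 3-hydroxyoxetan-3-yl gives an 8.1-fold lower number from compound 2 to compound 4 (0.91 log units; beyond the scatter). Among the compounds shown here, no earlier pair differed in this place, and this step shows that a group with no ring can stand here and give the stronger inhibitor. Nothing measured here accounts for the gain.

For the compounds shown here, the single step changes the ring, the chlorine and the donor count together, and these cannot be separated. As far as these compounds go, how a 1,2-dihydroxyethyl group without chlorine, or an amine, would behave in this place remains open.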